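Thiosemicarbazones on a Terpene Core: an Ortho Nitro Variant

The compounds below may be only part of what the source reports. "The series", "measured", "known", "first", "only" and "open" are said of these compounds alone.

Compound 1 `CC1=CC[C@H](C(C)(C)NC(=S)N/N=C/c2ccccc2)CC1` gives 8800 nM in a functional assay on HT-29 cells (Homo sapiens) for inhibition, read by sulforhodamine B assay, with a stated time of 48 h (a lower number here means a stronger inhibitor of growth, a higher number a weaker inhibitor of growth), the low end of the three numbers shown, though compound 3 sits inside the scatter of it. Compound 3 `CC1=CC[C@H](C(C)(C)NC(=S)N/N=C/c2ccc(Cl)cc2)CC1` gives 13600 nM, and compound 2 `CC1=CC[C@H](C(C)(C)NC(=S)N/N=C/c2ccc(N(C)C)cc2)CC1` gives 46500 nM. The step of a 1.5-fold higher number from compound 1 to compound 3 (0.19 log units; within the scatter) stays within the scatter, whereas the step of a 5.3-fold higher number from compound 1 to compound 2 (0.72 log units; beyond the scatter) lies beyond it. Compound 4 `CC1=CC[C@H](C(C)(C)NC(=S)N/N=C/c2ccccc2[N+](=O)[O-])CC1` carries a nitro in place of hydrogen on an aromatic carbon relative to compound 1, ortho to a large group. Both measured steps placed a group on the same ring and neither lowered the number, so the change from compound 1 to compound 4 is expected to be small or to raise the number slightly, as in a 1.4-fold higher number from compound 1 to compound 4 (0.13 log units; within the scatter). Compound 4 is therefore expected to give 12000 nM, within a range from 5000 nM to 35000 nM.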

Compound 4, concentration for 50% growth inhibition: 7900 nM
For compound 4 the middle estimate is 1.5-fold (0.18 log units) above the measured one; the measured number falls inside the stated range.
By their numbers in this assay, from the lowest: compounds 4, 1 and 3 (each within the scatter of the next); then compound 2.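

Replacing hydrogen with nitro on an aromatic carbon ortho to a large group gives a 1.1-fold lower number from compound 1 to compound 4 (0.05 log units; within the scatter) in this assay. Compound 4 is the first compound shown with a group at this position, and it shows that a nitro group of 3 heavy atoms can sit there without a step beyond the scatter. No measurement shown gives a reason for this result.

One group says little about the position as a whole: an amine or a carboxylic acid there could behave differently. From the compounds shown here alone, whether nitro would give a similar result elsewhere on the ring also stays open.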